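The source may hold more compounds than are shown below. What is called first, only, known or untested is meant among the compounds shown, and "the series" means these compounds.

Compound 1: `CC(C)(N)C(=O)N[C@H](COCc1ccccc1)c1nnnn1CCCc1ccccc1`, giving 17 nM in a functional assay on H4 cells for agonist activity at growth hormone secretagogue receptor type 1 (Homo sapiens), read by FLIPR; a higher number here means that more compound is needed for the effect, a lower number that less compound is needed.
Compound 2: `CC(C)(N)C(=O)N[C@H](COCc1ccccc1)c1nnnn1CCCCC#N`, giving 35 nM in this assay.

Among these two numbers compound 2 has the higher one, and the single measured step, a 2.1-fold higher number from compound 1 to compound 2 (0.31 log units; beyond the scatter), was modest. Compound 3, `CCCCNC(=O)CCCn1nnnc1[C@@H](COCc1ccccc1)NC(=O)C(C)(C)N`, has not been measured. It differs from compound 2 by butylcarbamoyl in place of cyanomethyl on a saturated chain carbon, three bonds along the chain from an aromatic nitrogen. Among the measured compounds shown here, the one measured step bears on it only loosely: it altered the same place, swapping a phenyl for a cyanomethyl, and gave a 2.1-fold higher number from compound 1 to compound 2 (0.31 log units; beyond the scatter). The new change is of another kind, bringing in an amide with one hydrogen-bond donor, so its effect cannot be read from that step. The expectation is therefore a small step, a 1.2-fold lower number from compound 2 to compound 3 (0.07 log units; within the scatter), with a wide range around it. Compound 3 is estimated at 30 nM in this assay, between 8 nM and 120 nM.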

Compound 3, half-maximal effective concentration: 30 nM
Beside the measured number, compound 3's estimate shows no gap at the digits printed; the range from low to high includes it.
By their numbers in this assay, from the lowest: compounds 1, 3 and 2 (each within the scatter of the next, the first and the last beyond it).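

The new compound shows that this place accepts a quite different group without a clear shift in this assay: butylcarbamoyl in place of cyanomethyl, with 7 heavy atoms instead of 3 and a hydrogen-bond donor where there was none, gives only a small step (a 1.2-fold lower number from compound 2 to compound 3 (0.07 log units; within the scatter)). Butylcarbamoyl in place of phenyl also stays within the scatter (a 1.8-fold higher number from compound 1 to compound 3 (0.25 log units; within the scatter)), so compound 3 cannot be told apart from either neighbour, even though compound 1 and compound 2 do differ beyond it. No measurement is available that would explain this result.

From the compounds shown here alone, an amine or a carboxylic acid at the end of this chain remains open, as does a much longer chain. So does the question of whether the amide hydrogen matters, which a tertiary amide could test.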